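A branched acid in place of a straight one

A few compounds are considered here, and "the series" means these few. Any claim that something is new, unique, unknown or untested is made for them only; others in the source may bear on it.

Measured so far:
compound 1, `O=C(O)CCC/C=C(/c1ccccc1)c1cccnc1`: 280 nM
compound 2, `C/C(=C\CCCCC(=O)O)c1cccnc1`: 210 nM
compound 3, `O=C(O)CCCC/C=C\c1cccnc1`: 250 nM

All three were tested in an assay (Equus caballus) for inhibition of Thromboxane-A synthase (Homo sapiens), using microsomes; a lower number here means a stronger inhibitor, a higher number a weaker inhibitor. Compound 1 shows the highest of the three numbers, yet its gaps to compound 3 and to compound 2 both fall inside the usual scatter of this assay, so the three compounds cannot be told apart on these data; none of them can be called the stronger or weaker inhibitor.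

Compound 4, `CC(C)(CCC/C=C(/c1ccccc1)c1cccnc1)C(=O)O`, differs from compound 1 in one place: 1-carboxy-1-methylethyl in place of carboxy on a saturated chain carbon, three bonds along the chain from a double-bonded chain carbon. The acid group itself is kept, with its single hydrogen-bond donor and acceptor, while the chain gains a branch carrying two methyl groups.

For the measured compounds named here, no step between two measured compounds is available here, so no measured change can guide the expectation for this move. The change is modest in size and keeps the acid, so the step expected from compound 1 to compound 4 in this assay, a 1.4-fold higher number from compound 1 to compound 4 (0.15 log units; within the scatter), is small, leaning toward a somewhat higher number, and may not exceed the scatter. Compound 4 is therefore estimated at 400 nM, within a range from 150 nM to 1200 nM.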

Compound 4, half-maximal inhibitory concentration: 30 nM
The estimate for compound 4 lay 13-fold (1.12 log units) above the measured number, and the stated range ends above it.
By their numbers in this assay, from the lowest: compound 4; then compounds 2, 3 and 1 (each within the scatter of the next).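

In this assay, 1-carboxy-1-methylethyl in place of carboxy on a saturated chain carbon, three bonds along the chain from a double-bonded chain carbon, lowers the number by a clear margin (a 9.3-fold lower number from compound 1 to compound 4 (0.97 log units; beyond the scatter)). For the compounds shown here, the earlier compounds offered no step at all, so this is the first sign that this end of the chain can move the number, even though the acid group is kept and the chain only gains a branch. Nothing available here explains the drop.

Going by these compounds, whether a single methyl group or a cyclopropane ring at this place would do the same remains open. So does whether the same branch would lower the number on compound 2 or compound 3, or whether a tetrazole could stand in for the acid.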